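A few compounds are considered here, and "the series" means these few. Any claim that something is new, unique, unknown or untested is made for them only; others in the source may bear on it.

Measured compounds:
Compound 1 `CC(=O)Nc1ccc(S(=O)(=O)NNC(=O)c2cccnc2Nc2ccc(Cl)cc2)cc1` — in a functional assay on OVCAR-8 cells (Homo sapiens) for antiproliferative activity (a lower number here means a stronger inhibitor of growth, a higher number a weaker inhibitor of growth), compound 1 gives > 100000 nM, which is a limit of the assay.
Compound 2 `O=C(NNS(=O)(=O)c1ccc(F)cc1)c1cccnc1Nc1ccc(Cl)cc1Cl` — in this assay compound 2 gives > 100000 nM, again a limit rather than a number.

Compound 1 thus stands at the limit, with no number of its own; the limit of > 100000 nM in this assay, at which 2 of the 2 values shown sit, describes the whole of what is shown. Compound 3 `O=C(NNS(=O)(=O)c1ccc(Cl)cc1Cl)c1cccnc1Nc1ccc(Cl)cc1` is the next analogue: 2,4-dichlorophenyl in place of 4-acetamidophenyl on a sulfonyl sulfur. Going by the values given here, no step between measured compounds exists to set a size, so compound 3 is expected to show no change beyond the scatter, a number no higher from compound 1 to compound 3 (the limit leaves the size open). Compound 3 is estimated at 100000 nM, between 20000 nM and 300000 nM, most likely reported only as a limit.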

Compound 3, concentration for total growth inhibition: 74100 nM
The estimate for compound 3 lay 1.3-fold (0.13 log units) above the measured number; measured number inside the range.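

In this assay, 2,4-dichlorophenyl in place of 4-acetamidophenyl on a sulfonyl sulfur gives an at least 1.3-fold lower number from compound 1 to compound 3 (0.13 log units; that floor lies within the scatter). Compound 3 is the only one of the three with a number of its own, 74100 nM, so a change at this position can bring the read-out inside the measurable range. On these data alone, the true size of the step stays unknown: the limit of > 100000 nM in this assay, at which 2 of the 3 values shown sit. As far as these compounds go, it remains open whether a morpholine or a simple methyl group on the sulfonyl sulfur would lower the number further, and which of the two chlorines in compound 3 matters.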